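Amide nitrogen substituent and HaCaT inhibition: estimate for compound 4

The source may hold more compounds than are shown below. What is called first, only, known or untested is meant among the compounds shown, and "the series" means these compounds.

Compound 1, `COc1cc(-c2cc(C(=O)O)c3ccccc3n2)ccc1OCC(=O)Nc1ccccc1`: in an ADME assay on HaCaT cells (Homo sapiens) for inhibition (on this read-out higher numbers stand for weaker inhibition and lower numbers for stronger inhibition), compound 1 gives > 300000 nM, which is a limit of the assay.
Compound 2, `COc1cc(-c2cc(C(=O)O)c3ccccc3n2)ccc1OCC(=O)Nc1ccccc1F`: compound 2 gives 161000 nM.
Compound 3, `COc1cc(-c2cc(C(=O)O)c3ccccc3n2)ccc1OCC(=O)Nc1ccc(C(F)(F)F)cc1`: compound 3 gives 150000 nM.

Compound 3 sits alongside compound 2, the two within the scatter of each other (a 1.1-fold lower number from compound 2 to compound 3 (0.03 log units; within the scatter)), while compound 1 reports only a limit (the limit of > 300000 nM in this assay, at which 1 of the 3 values shown sits). Fluoro in place of hydrogen on an aromatic carbon gives an at least 1.8-fold lower number from compound 1 to compound 2 (0.27 log units; that floor lies within the scatter), and trifluoromethyl in place of hydrogen on an aromatic carbon gives an at least 2.0-fold lower number from compound 1 to compound 3 (0.30 log units; that floor lies within the scatter); both floors lie within the scatter.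

Compound 4, `COc1cc(-c2cc(C(=O)O)c3ccccc3n2)ccc1OCC(=O)NCc1ccccc1`, differs from compound 3 by benzyl in place of 4-(trifluoromethyl)phenyl on an amide-type nitrogen. Among the measured compounds shown here, no measured step covers this change. For the measured compounds named here, the only measured steps show that removing a halogenated substituent from the aromatic ring on the amide nitrogen returns the number to the limit region of compound 1, and compound 4 carries no such substituent on its benzyl group. The number for compound 4 is therefore expected to rise, with a step of a 1.7-fold higher number from compound 3 to compound 4 (0.22 log units; within the scatter), possibly into the limit region. Compound 4 is estimated at 250000 nM, in a range from 100000 nM to 600000 nM.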

Compound 4, half-maximal inhibitory concentration in the HaCaT assay: > 300000 nM
Compound 4 ended at the assay's limit; the forecaster's own chance of this, stated with the estimate: 40%; middle value at least 1.2-fold (0.07 log units) from the limit.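

In the HaCaT assay, benzyl in place of 4-(trifluoromethyl)phenyl on the amide-type nitrogen gives an at least 2.0-fold higher number from compound 3 to compound 4 (0.30 log units; that floor lies within the scatter), and benzyl in place of 2-fluorophenyl gives an at least 1.8-fold higher number from compound 2 to compound 4 (0.27 log units; that floor lies within the scatter); the step from compound 1 to compound 4 cannot be read, both values being limits. Only compound 2 and compound 3, which carry fluorine in the group on the amide-type nitrogen, give values short of the limit, although the floors of their steps to the limit compounds lie within the scatter, and compound 4 sits with compound 1: the limit of > 300000 nM in the HaCaT assay, at which 2 of the 4 values shown sit. In a physicochemical assay for lipophilicity, using the shake flask method, in phosphate buffer, measured as octanol-water partition, at pH 7.4 (a lower number here means a more polar compound, a higher number a more lipophilic compound), compound 3 gives 1.6 and compound 4 gives 0.4; the same change is large here: the measured distribution coefficient of compound 3, 1.6, and of compound 4, 0.4, a number 1.20 log units lower (beyond the scatter).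

Open, as far as these compounds go, is whether the limit of compound 4 follows the loss of fluorine or the benzyl group itself, a question a 4-(trifluoromethyl)benzyl group on the amide-type nitrogen would address. Also open, from the compounds shown here alone, is how an amine on that ring would read in the HaCaT assay.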